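The compounds below may be only part of what the source reports. "The series", "measured", "known", "first", "only" and "open" are said of these compounds alone.

Measured so far in one cell assay:

compound 1, `COc1ccc(Nc2nc(SCc3cn(CC(=O)NC(=O)Nc4ccccn4)nn3)nc(-c3ccc(C(C)C)cc3)c2C#N)cc1`: 5420 nM
compound 2, `COc1ccc(Nc2nc(SCc3cn(CC(=O)NC(=O)Nc4ccccn4)nn3)nc(-c3ccc(C)cc3)c2C#N)cc1`: 5870 nM
compound 3, `CC(C)c1ccc(Nc2nc(SCc3cn(CC(=O)NC(=O)Nc4ccccn4)nn3)nc(-c3ccc(Cl)cc3)c2C#N)cc1`: > 64000 nM

All three were tested in a functional assay on ECa-109 cells (Homo sapiens) for inhibition, read by MTT assay, with a stated time of 72 h; a lower number here means a stronger inhibitor, a higher number a weaker inhibitor. Compound 1 gives 5420 nM, and compound 2 gives 5870 nM. The step between them, a 1.1-fold higher number from compound 1 to compound 2 (0.03 log units; within the scatter), comes from a single change, (methyl in place of isopropyl on an aromatic carbon). For compound 3 the assay reports only a limit, > 64000 nM, and this is the limit of > 64000 nM in this assay, at which 1 of the 3 values shown sits. How the core of compound 3 differs from the core of compound 1 is not broken down here.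

Compound 4, `Cc1ccc(Nc2nc(SCc3cn(CC(=O)NC(=O)Nc4ccccn4)nn3)nc(-c3ccc(Cl)cc3)c2C#N)cc1`, has not yet been measured in this assay. It differs from compound 3 by methyl in place of isopropyl on an aromatic carbon. For the measured compounds named here, this is the same change as the one from compound 1 to compound 2; the only wording that differs is the wider cut, which here reads (4-isopropylphenyl)amino to (4-methylphenyl)amino. That earlier step stayed within the scatter. The expectation for compound 4 is a step of similar size, a step that the limit leaves unreadable from compound 3 to compound 4, and it rests on the measured step of a 1.1-fold higher number from compound 1 to compound 2 (0.03 log units; within the scatter). With compound 3 sitting at a limit, compound 4 is expected to remain a weak inhibitor, estimated near 90000 nM, in a range from 30000 nM to 250000 nM, and it is likely that the assay will again report only a limit for compound 4.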

Compound 4, half-maximal inhibitory concentration: 13100 nM
The estimate for compound 4 lay 6.9-fold (0.84 log units) above the measured number; the measured number lies below the stated range.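

In this assay, the change from (4-isopropylphenyl)amino to (4-methylphenyl)amino on the core of compound 3 gives an at least 4.8-fold lower number from compound 3 to compound 4 (0.68 log units; beyond the scatter). As far as these compounds go, compound 3 reads > 64000 nM, which is a limit and not a number, so the true size of this step stays unknown and only its lower bound can be read. The step seen on one core therefore did not carry over to the other, although two cores cannot show why, or what the same change would do on a third core: the same change on two cores in this assay, a 1.1-fold higher number (0.03 log units; within the scatter) from compound 1 to compound 2 and an at least 4.8-fold lower number (0.68 log units; beyond the scatter) from compound 3 to compound 4, at least 5.2-fold (0.72 log units) apart, beyond the scatter of two such steps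

The compounds shown leave open how other groups would behave at this place on the ring, for example an ethyl group, a longer chain such as butyl, or a carboxylic acid, and whether the numbers would shift gradually from methyl to isopropyl. They also leave open whether compound 4, at 13100 nM, marks a real gain that could be built on, since a single pair gives no trend to follow.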